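Rearranging the Amide Substituent: Compound 2 to Compound 3

The source may hold more compounds than are shown below. What is called first, only, known or untested is meant among the compounds shown, and "the series" means these compounds.

Measured so far:
Compound 1, `CCN(C(=O)C1CCN(S(=O)(=O)c2ccc3c(c2)CCC3)CC1)[C@H](C)c1ccccc1`: 97%
Compound 2, `CCN(C(=O)C1CCN(S(=O)(=O)c2ccc3cn[nH]c3c2)CC1)[C@H](C)c1ccccc1`: 87%

Both compounds were tested in a functional assay on CHO cells for positive allosteric modulation of muscarinic acetylcholine receptor M5 (Homo sapiens), read by calcium flux; on this read-out lower numbers stand for smaller maximal responses and higher numbers for larger maximal responses. Compound 1 gives 97% and compound 2 gives 87%. For the measured compounds named here, the one measured step, a number 10 percentage points lower from compound 1 to compound 2 (within the scatter), swapped the group on the sulfonyl sulfur, 1H-indazol-6-yl in place of 2,3-dihydro-1H-inden-5-yl. Compound 2 therefore stands within the scatter of compound 1; the two cannot be told apart on these numbers.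

Compound 3, `CCN(Cc1ccccc1C)C(=O)C1CCN(S(=O)(=O)c2ccc3cn[nH]c3c2)CC1`, keeps the whole of compound 2 except at the amide-type nitrogen: 2-methylbenzyl in place of 1-phenylethyl on an amide-type nitrogen. Going by the values given here, no measured step touches that nitrogen, so nothing seen so far speaks for or against this change. Among the compounds with values here, with no relevant step, the expectation for compound 3 is a step of about a number 2 percentage points lower from compound 2 to compound 3 (within the scatter), none beyond the scatter. For compound 3 the estimated value is 85%, within 65% to 100%.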

Compound 3, largest response reached (reported as percent of maximum), in percent of the reference or control that the assay uses: 103%
The estimate for compound 3 lay 18 percentage points below the measured number; the whole stated range lies below it.
By their numbers in this assay, from the lowest: compounds 2, 1 and 3 (each within the scatter of the next, the first and the last beyond it).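

In this assay the amide-type nitrogen proves to be a place where the response can move, with a number 16 percentage points higher from compound 2 to compound 3 (beyond the scatter), the only step among these compounds that lies beyond the scatter. The two groups have the same count of heavy atoms and the same kind of aromatic ring, so joining the same atoms differently is enough to produce this step, and the defined stereocentre of 1-phenylethyl is not required for a high response in compound 3. No evidence is available to explain the step.

Going by these compounds, whether a plain benzyl or a 2-chlorobenzyl on the same nitrogen would give a similar response remains open, so the contribution of the methyl group of 2-methylbenzyl is unknown. On these data alone, it is also open whether 2-methylbenzyl would have the same effect with 2,3-dihydro-1H-inden-5-yl on the sulfonyl sulfur.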